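Taking the side group off compound 1

A few compounds are considered here, and "the series" means these few. Any claim that something is new, unique, unknown or untested is made for them only; others in the source may bear on it.

Compound 1 `C=CS(=O)(=O)N[C@@H]1CCN(S(=O)(=O)c2c(C(N)=O)[nH]c3ccc(Br)cc23)C1` gives 2100 nM
Compound 2 `C=CC(=O)N1CCC[C@@H](NS(=O)(=O)c2c(C(N)=O)[nH]c3ccc(Br)cc23)C1` gives 43600 nM

Both numbers come from an ADME assay on MT4 cells (Homo sapiens) for cytotoxicity, read by MTT assay, with a stated time of 5 days; a higher number here means that more compound is tolerated, a lower number that less compound is tolerated. Compound 1 holds the lower of the two, and its gap to compound 2 lies beyond the usual scatter, so so far it is the less tolerated compound.

Compound 3 `NC(=O)c1[nH]c2ccc(Br)cc2c1S(=O)(=O)N1CCCC1` keeps the core of compound 1 but loses a side group. The change hydrogen in place of (vinylsulfonyl)amino on a saturated ring carbon puts hydrogen in place of (vinylsulfonyl)amino on a saturated ring carbon. For the measured compounds named here, no measured pair shows this change alone, so the guide is indirect: compound 2, which has no (vinylsulfonyl)amino group, gives 43600 nM in this assay and sets the expected direction. The step is expected to go upward and beyond the scatter, and the estimate is a 14-fold higher number from compound 1 to compound 3 (1.15 log units; beyond the scatter) for it. For compound 3 the estimated value is 30000 nM with 8000 nM as the expected lower end and 100000 nM as the expected upper end.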

Compound 3, half-maximal cytotoxic concentration: 35300 nM
Compound 3: the middle estimate sits 1.2-fold (0.07 log units) below what was measured; low and high end bracket the measured number.
By their numbers in this assay, from the lowest: compound 1; then compounds 3 and 2 (each within the scatter of the next).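

For the compounds shown here, compound 3 gives the first direct reading at this position. Going by these compounds alone, only one place changes between compound 1 and compound 3. In this assay there is a 17-fold higher number from compound 1 to compound 3 (1.23 log units; beyond the scatter) when hydrogen replaces (vinylsulfonyl)amino on a saturated ring carbon, a large step and beyond the scatter. The earlier comparison could only hint at this, since compound 1 and compound 2 differ in more than one place; this pair ties the lower tolerance of compound 1 to the (vinylsulfonyl)amino group itself.

Still open, on these data alone, is whether a plain amine, a carboxylic acid or a longer alkyl chain on this ring carbon would behave like hydrogen or like (vinylsulfonyl)amino, and whether the vinyl part or the sulfonylamino part matters more. Why the number moves this way also stays unexplained, as no supporting measurement bears on it.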